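Swapping the Linker Arm on a Fused Oxygen Core

The source may hold more compounds than are shown below. What is called first, only, known or untested is meant among the compounds shown, and "the series" means these compounds.

Compound 1, `CCCc1ccc(C#Cc2cc3cn([C@H]4C[C@H](O)[C@@H](CO)O4)c(=O)nc3o2)cc1`, in an ADME assay on HEL cells (Homo sapiens) for cytotoxicity, with a stated time of 3 days (a lower number here means that less compound is tolerated, a higher number that more compound is tolerated), gives 87000 nM.
Compound 2, `Cc1ccc(C#Cc2cc3cn([C@H]4C[C@H](O)[C@@H](CO)O4)c(=O)nc3o2)cc1`, in this assay reaches only the limit >= 510000 nM, not a number.
Compound 3, `Cc1ccc(CCc2cc3cn([C@H]4C[C@H](O)[C@@H](CO)O4)c(=O)nc3o2)cc1`, in this assay gives 540000 nM.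

All three compounds share the same core and differ only in the arm attached to it. Compound 3 stands highest of the two readable numbers, with compound 1 nearest below it. The step of an at least 5.8-fold higher number from compound 1 to compound 2 (0.76 log units; beyond the scatter) shows that a shorter chain on the ring tip is tolerated at a higher concentration. The step that the limit leaves unreadable from compound 2 to compound 3 cannot be sized, since compound 2 sits at the limit of >= 510000 nM in this assay, at which 1 of the 3 values shown sits.

Compound 4, `O=c1nc2oc(C#Cc3ccccc3)cc2cn1[C@H]1C[C@H](O)[C@@H](CO)O1`, has not yet been measured. Its change from compound 3 is 2-phenylethynyl in place of 2-(4-methylphenyl)ethyl on an aromatic carbon. Both measured steps bear on it, but only the first has a readable size, and it points toward a higher number when the arm carries less at its tip. The expected step is therefore small or none beyond the scatter, a 1.1-fold lower number from compound 3 to compound 4 (0.03 log units; within the scatter), with a real chance that only a limit is reported. Compound 4 is estimated at 500000 nM, with a range from 150000 nM to 1500000 nM.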

Compound 4, minimum cytotoxic concentration: > 570000 nM
Compound 4: no number, only a limit; the forecaster's own chance of this, stated with the estimate: 55%; middle value at least 1.1-fold (0.05 log units) away from the limit.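

In this assay compound 4 reaches only the limit > 570000 nM, not a number. Removing the propyl group altogether while keeping the triple bond gives an at least 6.5-fold higher number from compound 1 to compound 4 (0.81 log units; beyond the scatter), so an arm ending in a plain phenyl ring is clearly better tolerated than the propyl-bearing arm of compound 1. Exchanging 2-(4-methylphenyl)ethyl for 2-phenylethynyl on this aromatic carbon, next to the ring oxygen, gives an at least 1.0-fold higher number from compound 3 to compound 4 (0.02 log units; that floor lies within the scatter); that floor shows no loss of tolerance, yet it cannot establish a real gain, so a triple-bonded arm without a tip group can do as well here as a saturated arm carrying a methyl.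

Going by these compounds, the steps from compound 2 to compound 3 and from compound 2 to compound 4 cannot be read, so the effect of the methyl group alone on the triple-bonded arm remains unsized, and the true ceiling of tolerance in these compounds is unknown. The compounds shown also leave open whether the drop seen with propyl continues with a longer chain such as hexyl, and how an amine or a carboxylic acid at the tip of the arm would behave in this assay.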